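Chain end on the shared core: nitrile out, methoxycarbonyl in

The compounds below may be only part of what the source reports. "The series", "measured", "known", "first", "only" and "open" are said of these compounds alone.

In a functional assay on LoVo cells (Homo sapiens) for cytotoxicity, read by colorimetric assay and MTT assay (on this read-out lower numbers stand for stronger inhibition and higher numbers for weaker inhibition), compound 1 `COc1cccc2cc(-c3ccccc3)c(O)nc12` gives 10000 nM. Compound 2 `COc1ccc(-c2cc3c(OC)cc(OC)cc3n(CC#N)c2=O)cc1` gives 10000 nM. Compound 3 `COc1ccc(-c2cc3c(OC)cc(OC)cc3n(CCCC#N)c2=O)cc1` gives 10000 nM, level with both others. Compound 4 `COC(=O)CCn1c(=O)c(-c2ccc(OC)cc2)cc2c(OC)cc(OC)cc21` is still unmeasured. It differs from compound 3 as follows: methoxycarbonyl in place of cyanomethyl on a saturated chain carbon, two bonds along the chain from an aromatic nitrogen. In words, this is methoxycarbonyl in place of cyanomethyl on a saturated chain carbon, two bonds along the chain from an aromatic nitrogen. Among the measured compounds shown here, the only measured step bearing on this chain is no change at the digits printed from compound 2 to compound 3 (within the scatter). For the measured compounds named here, that step keeps the nitrile, so no measured step replaces it. No step beyond the scatter, in either direction, is therefore expected in this assay. The estimated step is no change at the digits printed from compound 3 to compound 4 (within the scatter). Compound 4 is expected at 10000 nM, with an estimated range of 5000 nM to 20000 nM.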

Compound 4, half-maximal inhibitory concentration: 10000 nM
Compound 4: middle estimate and measured number agree at the digits printed; the measured number falls inside the stated range.
By their numbers in this assay, from the lowest: compounds 1, 2, 3 and 4 (each within the scatter of the next).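

Swapping the nitrile for methoxycarbonyl at the chain end, on a saturated chain carbon two bonds along the chain from an aromatic nitrogen, gives no change at the digits printed from compound 3 to compound 4 (within the scatter) in this assay and leaves the chain end with a different group for the first time. The comparison with the shorter nitrile chain gives no change at the digits printed from compound 2 to compound 4 (within the scatter) on the same read-out, so neither chain end separates these compounds. No supporting data offer an explanation for this flat result.

Going by these compounds, a carboxylic acid, an amine or a longer chain at this chain end remains open. Whether any group here can move compound 4 away from 10000 nM is also unresolved.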